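Cytotoxicity notes on the benzylpiperidine carboxamide series

The source may hold more compounds than are shown below. What is called first, only, known or untested is meant among the compounds shown, and "the series" means these compounds.

Measured compounds:
compound 1, `COC(=O)C[C@H](NC(=O)OC(C)(C)C)C(=O)N(Cc1ccc(F)cc1)C1(C(=O)NCc2ccccc2)CCN(Cc2ccccc2)CC1`: > 100000 nM
compound 2, `COC(=O)CCC(=O)N(Cc1ccc(F)cc1)C1(C(=O)NCc2ccccc2)CCN(Cc2ccccc2)CC1`: 16000 nM

In an ADME assay on MDCK cells (Canis lupus familiaris) for cytotoxicity, read by microscopy, with a stated time of 72 h (on this read-out lower numbers stand for higher toxicity in this test and higher numbers for lower toxicity in this test), compound 1 gives only a limit, > 100000 nM. Going by the values given here, compound 2 gives the one real number in this assay, 16000 nM. Among the compounds with values here, the single measured step, an at least 6.2-fold lower number from compound 1 to compound 2 (0.79 log units; beyond the scatter), shows that removing the (tert-butoxycarbonyl)amino group from the acyl side chain brings the number down from the limit to a value inside the range of the assay; the limit itself, (the limit of > 100000 nM in this assay, at which 1 of the 2 values shown sits), leaves the true size of that step open.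

Compound 3, `C[C@H](NC(=O)OC(C)(C)C)C(=O)N(Cc1ccc(F)cc1)C1(C(=O)NCc2ccccc2)CCN(Cc2ccccc2)CC1`, has not yet been measured. It differs from compound 2 by 1-((tert-butoxycarbonyl)amino)ethyl in place of 2-(methoxycarbonyl)ethyl on a carbonyl carbon. This change reinstates the (tert-butoxycarbonyl)amino group, so the step from compound 1 to compound 2 bears on it in reverse. An upward step of about that size is expected, a 5.0-fold higher number from compound 2 to compound 3 (0.70 log units; beyond the scatter), with a fair chance that the assay again reports only a limit. Compound 3 is therefore expected at 80000 nM, within 25000 nM to 250000 nM.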

Compound 3, minimum cytotoxic concentration: > 100000 nM
Compound 3: no number, only a limit; the forecaster's own chance of this, stated with the estimate: 45%; at least 1.2-fold (0.09 log units) between middle value and limit.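

In this assay, an at least 6.2-fold higher number from compound 2 to compound 3 (0.79 log units; beyond the scatter) shows that the number at this carbonyl carbon also rises when 1-((tert-butoxycarbonyl)amino)ethyl replaces 2-(methoxycarbonyl)ethyl, a change in which the methoxycarbonyl group is lost. Compound 3 gives only a limit, > 100000 nM. The two compounds shown with the (tert-butoxycarbonyl)amino group therefore both reach the limit, with or without methoxycarbonyl, and the step between compound 1 and compound 3 cannot be read: the limit of > 100000 nM in this assay, at which 2 of the 3 values shown sit.

Going by these compounds, how far the true values of compound 1 and compound 3 lie past that limit remains open. Also open, on these data alone, is whether a free amine in place of the (tert-butoxycarbonyl)amino group would stay at the limit or give a number in the range of compound 2, which would show how much depends on the protecting group itself.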